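Solubility notes on an amine-side change

This account rests on a few compounds, and the source may have more. Where it says the series, first, only, none or still open, it means among the compounds named here.

Measured so far:
Compound 1 `CC(C)Nc1nc(NCc2ccco2)c2ccccc2n1` gives >= 30000 nM in a physicochemical assay for solubility, at pH 2 (a lower number here means a less soluble compound, a higher number a more soluble compound), a limit of the assay.
Compound 2 `OCCNc1nc(NCc2ccco2)c2ccccc2n1` gives >= 30000 nM in this assay, again a limit.

Among the compounds with values here, compound 1 stands only at a limit in this assay; the one other value shown is also a limit, so its place among real numbers is not fixed. The measured step that the two limits leave unreadable from compound 1 to compound 2 cannot be read because the limit of >= 30000 nM in this assay, at which 2 of the 2 values shown sit, holds both of its ends. Compound 3 `CSCCNc1nc(NC(C)C)nc2ccccc12` differs from compound 1 by (methylsulfanyl)methyl in place of furan-2-yl on a saturated chain carbon bound to a nitrogen on an aromatic ring. Within the data shown here, no measured step covers this change; the only step available, from compound 1 to compound 2, is unreadable and concerns a different position. The expectation for compound 3 in this assay is therefore no step beyond the scatter, with the value most likely again at the limit: the estimated step is a number no higher from compound 1 to compound 3 (the limit leaves the size open). Compound 3 is expected at 30000 nM, within 10000 nM to 60000 nM.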

Compound 3, solubility: >= 30000 nM
Compound 3 ended at the assay's limit (the forecaster's own chance of this, stated with the estimate: 70%); the middle value sits exactly at the limit.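

The steps from compound 1 to compound 3 and from compound 1 to compound 2 cannot be read in this assay: the limit of >= 30000 nM in this assay, at which 3 of the 3 values shown sit. Compound 1, compound 2 and compound 3 leave open where their real values lie and whether either change shifts them at all.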